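A few compounds are considered here, and "the series" means these few. Any claim that something is new, unique, unknown or untested is made for them only; others in the source may bear on it.

In a functional assay on BXPC-3 cells (Homo sapiens) for inhibition, read by MTT assay, with a stated time of 7 days (on this read-out higher numbers stand for weaker inhibition and lower numbers for stronger inhibition), compound 2, with the structure `CCOC(=O)[C@@H]1C[C@H](O)CN(S(=O)(=O)c2ccc(S(=O)(=O)N(CC)CC)cc2)C1`, gives 3300 nM. Among the compounds with values here, this is the highest number among the three compounds measured so far, which on this read-out means the weakest inhibition of the set. Compound 3, with the structure `CCOC(=O)[C@@H]1CCCN(S(=O)(=O)c2ccc(S(=O)(=O)N(CC)CC)cn2)C1`, gives 1400 nM in this assay, and the gap from compound 2 lies beyond the usual scatter. Compound 1, with the structure `CCN(CC)S(=O)(=O)c1ccc(S(=O)(=O)N2CCC[C@@H](C(=O)N[C@@H]3CCN(C(=O)OC(C)(C)C)C3)C2)cc1`, gives 400 nM, and here the distance from compound 2 is widest, again beyond the scatter.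

Compound 4, with the structure `CCOC(=O)[C@@H]1C[C@@H](O)CN(S(=O)(=O)c2ccc(S(=O)(=O)N(CC)CC)cc2)C1`, has not yet been measured. Its relation to compound 2 is simple: the two compounds have the same atoms and bonds and differ only in configuration as drawn: 1 of 2 stereo elements differ; a stereocentre at a saturated ring carbon is drawn S in compound 2 and R in compound 4. Within the data shown here, no measured pair in this set shows what such a change in configuration does in this assay, so there is no direct precedent to lean on. Without a shown step, the reasonable expectation is a modest move, possibly in either direction, and not clearly beyond the scatter. The estimated step from compound 2 to compound 4 is therefore a 1.1-fold lower number from compound 2 to compound 4 (0.04 log units; within the scatter). Compound 4 is expected to give about 3000 nM in this assay, with a plausible range from 1000 nM to 9000 nM.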

Compound 4, half-maximal inhibitory concentration: 10800 nM
Estimate against measurement, compound 4: 3.6-fold (0.56 log units) below, and the stated range ends below it.
By their numbers in this assay, from the lowest: compound 1; then compound 3; then compound 2; then compound 4.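

This pair gives the first measure of what configuration alone does in this assay: the step is a 3.3-fold higher number from compound 2 to compound 4 (0.51 log units; beyond the scatter) and lies beyond the usual scatter, with the lower number going with the S drawing at the saturated ring carbon. Nothing enters or leaves, so the gap can be traced to a single source, because nothing else separates the two structures: the fact that compounds 2 and 4 differ only in the configuration as drawn. The configuration at this saturated ring carbon therefore matters on this read-out, although the finding rests on this one pair and does not establish a pattern beyond it.

The compounds shown leave open whether the other stereo element, which is drawn alike in the two compounds, matters as much, and whether the same change in configuration would have an effect of similar size or direction on a different core. From the compounds shown here alone, it also remains open whether a methoxy group or an amine in place of the hydroxyl would preserve this difference between the two configurations.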